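This account rests on a few compounds, and the source may have more. Where it says the series, first, only, none or still open, it means among the compounds named here.

Measured so far:
- compound 1 `CC(C)(CCl)C(=O)Nc1ccc(C2=NNC(=O)CC2)cc1`: 11.4 ug/mL
- compound 2 `C=CCNCC(=O)Nc1ccc(C2=NNC(=O)CC2)cc1`: about 21.5 ug/mL

Both values come from a functional assay for inhibition, with Homo sapiens as the target; a lower number here means that less compound is needed, a higher number that more compound is needed for the effect. For the measured compounds named here, compound 2 is one of only two measured numbers and lies within the scatter of compound 1 at 11.4 ug/mL.

Compound 3 `C[N+]1(CC(=O)Nc2ccc(C3=NNC(=O)CC3)cc2)CCCC1` has not yet been measured. The change is a group of 6 heavy atoms (5 carbon, 1 nitrogen; one five-membered non-aromatic ring with 1 hetero atom) in place of a group of 4 heavy atoms (3 carbon, 1 nitrogen; no ring), on a saturated chain carbon bound to a carbonyl carbon. The allylamino group leaves with no net charge, and the entering group has a net charge of +1.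

Going by the values given here, only one measured step bears on this: a 1.9-fold higher number from compound 1 to compound 2 (0.28 log units; within the scatter). It also exchanged a group on a carbonyl carbon and stayed within the scatter. Neither measured compound carries a net charge, so this step is a weak guide and the range is kept wide. No step beyond the scatter is expected, and no direction can be assigned. The expected step is a 1.2-fold higher number from compound 2 to compound 3 (0.07 log units; within the scatter). For compound 3 the estimate is 25 ug/mL, with an expected range of 8 ug/mL to 80 ug/mL.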

Compound 3, half-maximal effective concentration: > 46.4 ug/mL
Compound 3 was reported as a limit (the forecaster's own chance of this, stated with the estimate: 15%); middle value at least 1.8-fold (0.26 log units) from the limit.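

The exchange on the saturated chain carbon bound to a carbonyl carbon now moves the number beyond the scatter, which the earlier step within the series did not do: an at least 2.1-fold higher number from compound 2 to compound 3 (0.33 log units; beyond the scatter), and an at least 4.0-fold higher number from compound 1 to compound 3 (0.60 log units; beyond the scatter), both in this assay. The entering group differs from allylamino at once in ring, heavy-atom count, hydrogen-bond donors and net charge, so the shift cannot be assigned to any one of these. Compound 3 is reported only as a limit: the limit of > 46.4 ug/mL in this assay, at which 1 of the 3 values shown sits.

Still open, as far as these compounds go, is how a tertiary amine with no net charge, carrying the same five-membered ring, compares with compound 3, which would separate the ring from the charge. A carboxylic acid on the same carbon would show whether a net charge of the opposite sign gives a similar result.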